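Carbamate oxygen substituent: compound 3 in the series

A few compounds are considered here, and "the series" means these few. Any claim that something is new, unique, unknown or untested is made for them only; others in the source may bear on it.

Measured so far in an assay on COS-7 cells for inhibition of patatin-like phospholipase domain-containing protein 2 (Mus musculus), tested at 200 uM; a higher number here means more inhibition at the concentration tested (going by the name of the read-out), a lower number less inhibition:
compound 1 `CC(C)OC(=O)Nc1cccc(-c2ccc(N(C)C)cc2)c1` — 69%
compound 2 `CC(C)COC(=O)Nc1cccc(-c2ccc(N(C)C)cc2)c1` — 90%

For the measured compounds named here, compound 2 stands highest of the two numbers in this assay; compound 1 sits a number 21 percentage points higher from compound 1 to compound 2 (beyond the scatter) behind it, the one measured step, and it is beyond the scatter.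

Compound 3 `CN(C)c1ccc(-c2cccc(NC(=O)Oc3ccccc3)c2)cc1` is not yet measured. It differs from compound 2 by phenyl in place of isobutyl on an oxygen next to a carbonyl group.

Going by the values given here, only the step from compound 1 to compound 2 bears on this, and it too swaps the group on the oxygen next to a carbonyl group; it was modest, a number 21 percentage points higher from compound 1 to compound 2 (beyond the scatter). Among the compounds with values here, a phenyl at that oxygen has no precedent here, so no direction can be read from the two measured compounds, and a step of no more than modest size is expected, either way. For compound 3 the estimate in this assay is 78% (range 55% to 95%), which would mean an expected step of a number 12 percentage points lower from compound 2 to compound 3 (beyond the scatter).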

Compound 3, a percentage reported as inhibition, at one concentration (the size of the read-out at that concentration, not a potency): 75%
For compound 3 the middle estimate is 3 percentage points above the measured one; low and high end bracket the measured number.
By their numbers in this assay, from the lowest: compounds 1 and 3 (each within the scatter of the next); then compound 2.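

In this assay, phenyl is the only ring among the compounds shown on an oxygen next to a carbonyl group, and it still leaves clear inhibition, with isobutyl replaced at a cost of a number 15 percentage points lower from compound 2 to compound 3 (beyond the scatter) in the read-out. Set against isopropyl, the same phenyl gives a number 6 percentage points higher from compound 1 to compound 3 (within the scatter) and so cannot be told apart from it, which leaves isobutyl as the one group here standing clear of both others. No measured evidence available here accounts for this difference between the groups.

Still open, as far as these compounds go, is whether a benzyl, a cyclohexyl or a longer chain such as n-butyl on this oxygen would match or pass isobutyl. From the compounds shown here alone, it is equally open whether a phenyl carrying a methoxy or a fluorine would recover the lost inhibition.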